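Compound 1 to compound 3: phenyl to benzyl

A few compounds are considered here, and "the series" means these few. Any claim that something is new, unique, unknown or untested is made for them only; others in the source may bear on it.

- compound 1 `Cc1nnc(C2CCN(c3ccccn3)CC2)n1-c1ccccc1`: < 8 mL.min-1.g-1
- compound 2 `Cc1ccc(-n2c(C)nnc2C2CCN(c3ccccn3)CC2)cc1`: 40 mL.min-1.g-1

In an in vitro ADME assay on microsomes from liver (Homo sapiens) for metabolic stability (a lower number here means slower removal, a higher number faster removal of the compound), compound 1 gives < 8 mL.min-1.g-1, which is a limit of the assay and not a number. The next compound, compound 3 `Cc1nnc(C2CCN(c3ccccn3)CC2)n1Cc1ccccc1`, carries benzyl in place of phenyl on an aromatic nitrogen. Among the compounds with values here, the one measured step that bears on this is methyl in place of hydrogen on an aromatic carbon, an at least 5.0-fold higher number from compound 1 to compound 2 (0.69 log units; beyond the scatter), which lies beyond the scatter. It is a different change, so it supports only the direction: a rise is expected in this assay. The expected step is an at least 2.7-fold higher number from compound 1 to compound 3 (0.43 log units; beyond the scatter). Compound 3 is estimated at 22 mL.min-1.g-1, with an expected range of 8 mL.min-1.g-1 to 70 mL.min-1.g-1.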

Compound 3, intrinsic clearance in microsomes: < 8 mL.min-1.g-1
Compound 3 gave a limit, no number; the forecaster's own chance of this, stated with the estimate: 20%; middle value at least 2.7-fold (0.43 log units) from the limit.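

In this assay, benzyl in place of 4-methylphenyl on the aromatic nitrogen gives an at least 5.0-fold lower number from compound 2 to compound 3 (0.69 log units; beyond the scatter). The rise seen with the 4-methylphenyl group therefore does not appear with benzyl, and this position accepts one added carbon in the form of benzyl without leaving the limit. The step from phenyl to benzyl cannot be read, and any difference between them stays hidden: the limit of < 8 mL.min-1.g-1 in this assay, at which 2 of the 3 values shown sit.

From the compounds shown here alone, whether a methyl on the benzyl ring would raise the number as it does on phenyl remains open. Also open, going by these compounds, is how a longer chain such as phenethyl, or an amine, would read at this nitrogen.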